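The source may hold more compounds than are shown below. What is called first, only, known or untested is meant among the compounds shown, and "the series" means these compounds.

Measured so far in an in vitro functional assay on HEK293-A cells for positive allosteric modulation of metabotropic glutamate receptor 5 (Homo sapiens), read by FLIPR and calcium flux; a higher number here means that more compound is needed for the effect, a lower number that less compound is needed:
- compound 1 `Cc1ccc(N2CC(c3nc(-c4cccc(C(F)(F)F)c4)no3)CC2=O)cc1` gives 3400 nM
- compound 2 `Cc1ccc(N2CC(c3nc(-c4cccc(C)c4)no3)CC2=O)cc1` gives 1300 nM

Among the compounds with values here, of these two numbers, compound 2 holds the lower one; the single measured step between them is a 2.6-fold lower number from compound 1 to compound 2 (0.42 log units; beyond the scatter), which came with methyl in place of trifluoromethyl on an aromatic carbon. Within the data shown here, that is the only step known here, and it shows that exchanging the group at this position of the shared core can move the read-out beyond the usual scatter.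

Compound 3 `Cc1ccc(N2CC(c3nc(-c4cccc(F)c4)no3)CC2=O)cc1` has not yet been measured in this assay. It differs from compound 2 by fluoro in place of methyl on an aromatic carbon. Among the measured compounds shown here, the step of a 2.6-fold lower number from compound 1 to compound 2 (0.42 log units; beyond the scatter) bears on this position, since it changed the same group, but no fluoro-bearing compound has been measured, so the direction of the new step is not fixed by the data. Because a 2.6-fold lower number from compound 1 to compound 2 (0.42 log units; beyond the scatter) was modest, the expected step of a 1.4-fold higher number from compound 2 to compound 3 (0.14 log units; within the scatter) is set near no change, leaning a little toward a higher number. Compound 3 is therefore estimated at 1800 nM, with an expected range from 700 nM to 4500 nM.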

Compound 3, half-maximal effective concentration: 1200 nM
Estimate against measurement, compound 3: 1.5-fold (0.18 log units) above; the measured number falls inside the stated range.
By their numbers in this assay, from the lowest: compounds 3 and 2 (each within the scatter of the next); then compound 1.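

In this assay, the change from 3-methylphenyl to 3-fluorophenyl comes with a 1.1-fold lower number from compound 2 to compound 3 (0.03 log units; within the scatter), so fluoro and methyl cannot be told apart at this position of the shared core. What the earlier pair could not show is that the move away from trifluoromethyl is not tied to methyl alone: fluoro in its place gives a 2.8-fold lower number from compound 1 to compound 3 (0.45 log units; beyond the scatter), a step much like the earlier 2.6-fold lower number from compound 1 to compound 2 (0.42 log units; beyond the scatter), so trifluoromethyl stands apart from both of the other groups tested here. The data on hand offer no measured explanation for this result.

Still open, going by these compounds, is what other groups would do on this aromatic carbon, for example a plain hydrogen, an amine, a carboxylic acid or a longer chain such as propyl, and whether any of them would give a number clearly lower than those of compound 2 and compound 3. Also open, on these data alone, is whether the same groups would compare in the same way at another place on this ring, since all three compounds carry their group meta to a large group.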